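The source may hold more compounds than are shown below. What is called first, only, known or untested is meant among the compounds shown, and "the series" means these compounds.

Measured compounds in a functional assay on HeLa cells (Homo sapiens) for cytotoxicity, read by sulforhodamine B assay, with a stated time of 48 h; on this read-out higher numbers stand for weaker inhibition and lower numbers for stronger inhibition:
- compound 1 `CC1=C(/C=C/C(=O)/C=C/c2ccccc2)C(C)(C)CCC1`: 70200 nM
- compound 2 `CC1=C(/C=C/C(=O)/C=C/c2ccc(Cl)cc2)C(C)(C)CCC1`: 33200 nM
- compound 3 `CC1=C(/C=C/C(=O)/C=C/c2ccccc2C)C(C)(C)CCC1`: this is a limit of the assay, > 100000 nM; see the limit of > 100000 nM in this assay, at which 1 of the 3 values shown sits.

Compound 2 holds the lowest of the two numbers in this assay; its nearest neighbour is compound 1, and the step of a 2.1-fold lower number from compound 1 to compound 2 (0.33 log units; beyond the scatter) places that gap beyond the scatter. Compound 3 reports only the limit, and the steps of an at least 1.4-fold higher number from compound 1 to compound 3 (0.15 log units; that floor lies within the scatter) and an at least 3.0-fold higher number from compound 2 to compound 3 (0.47 log units; beyond the scatter) are therefore floors rather than numbers.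

Compound 4 `CC1=C(/C=C/C(=O)/C=C/c2ccc(Cl)c(Cl)c2)C(C)(C)CCC1` differs from compound 2 by chloro in place of hydrogen on an aromatic carbon. Among the compounds with values here, the only measured step of the same kind is a 2.1-fold lower number from compound 1 to compound 2 (0.33 log units; beyond the scatter), a modest lowering on adding a chloro to the same ring. The steps to compound 3 concern a methyl and do not bear directly on a second chloro.

A second chloro is therefore expected to give at most a modest further lowering, possibly none beyond the scatter, which for compound 4 is expected as a 1.7-fold lower number from compound 2 to compound 4 (0.22 log units; within the scatter). Compound 4 is expected to give 20000 nM in this assay, within a range of 8000 nM to 50000 nM.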

Compound 4, half-maximal inhibitory concentration: > 100000 nM
Compound 4: a limit, no number (the forecaster's own chance of this, stated with the estimate: 5%); middle value at least 5.0-fold (0.69 log units) away from the limit.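

In this assay, a chloro added to a ring that already carries one does not repeat the earlier lowering: the new step reads an at least 3.0-fold higher number from compound 2 to compound 4 (0.47 log units; beyond the scatter), whereas the first chloro gave a 2.1-fold lower number from compound 1 to compound 2 (0.33 log units; beyond the scatter). Compound 4 gives > 100000 nM, which is a limit of the assay and not a number, so the new step is a floor and its true size cannot be read. A chloro at this place, ortho to a chloro group and meta to a large group, thus takes the series from a measurable value to the limit, where compound 3 also stands: the limit of > 100000 nM in this assay, at which 2 of the 4 values shown sit.

How compound 3 and compound 4 rank against each other cannot be read from two limits. From the compounds shown here alone, whether a fluoro, a methoxy or an amine at this same place would keep a measurable value remains open.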